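The source may report more compounds than this note shows. Statements on the series, on what has been measured and on what is new or still open speak of the compounds shown alone.

Compound 2 `CC(C)=CCC/C(C)=C/CC1Cc2c(O)cc(=O)n(CCCO)c2CC1(C)C` gives 0% in a functional assay on PANC-1 cells (Homo sapiens) for inhibition, read by MTT assay, with a stated time of 24 h, tested at 10 uM; a lower number here means less inhibition, a higher number more inhibition at the concentration tested (going by the name of the read-out). Compound 1 `CC(C)=CCC1Cc2c(O)cc(=O)n(CCCO)c2CC1(C)C` gives 0% and compound 3 `CC(C)=CCC1Cc2c(OC(=O)Nc3ccc(F)c(F)c3)cc(=O)n(CCCO)c2CC1(C)C` gives 0%; compound 2 thus stands level with both at the digits shown, neither nearer nor further from either in any meaningful sense. Compound 4 `CC(C)=CCC/C(C)=C/CC1Cc2c(OC(=O)Nc3ccc(F)c(Cl)c3)cc(=O)n(CCCO)c2CC1(C)C` has not been measured. It differs from compound 2 by (3-chloro-4-fluorophenyl)carbamoyl in place of hydrogen on an oxygen on an aromatic ring. Going by the values given here, two measured steps bear on this change: no change at the digits printed from compound 1 to compound 2 (within the scatter) covers the chain extension that compound 2 already carries, and no change at the digits printed from compound 1 to compound 3 (within the scatter) is the closest parallel to the change in hand, a carbamoyl in place of hydrogen on an oxygen on an aromatic ring. Both steps were within the scatter. No movement beyond the scatter is therefore expected; the estimated step is no change at the digits printed from compound 2 to compound 4 (within the scatter). Compound 4 is expected to give 0%, within 0% to 12%.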

Compound 4, a percentage reported as inhibition, at one concentration (the size of the read-out at that concentration, not a potency): 0%
Estimate against measurement, compound 4: no gap at the digits printed, within the range that was stated.
By their numbers in this assay, from the lowest: compounds 1, 2, 3 and 4 (each within the scatter of the next).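

On the longer-chain compound, the hydroxy to ((3-chloro-4-fluorophenyl)carbamoyl)oxy exchange gives no change at the digits printed from compound 2 to compound 4 (within the scatter) in this assay. The carbamoyl exchange on an oxygen on an aromatic ring therefore leaves the reading unmoved on this longer chain as well, now with a chlorine-bearing phenyl group. No available evidence accounts for this flat result.

With all readings level, this position offers no measured trend to follow. From the compounds shown here alone, whether an amine or a carboxylic acid on the carbamoyl phenyl ring would give any inhibition in this assay remains open.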